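This account rests on a few compounds, and the source may have more. Where it says the series, first, only, none or still open, it means among the compounds named here.

Three compounds share one core and differ mainly in the group attached to the carbonyl carbon. Compound 1 `CCC/C=C/C(=O)N(Cc1ccc(OC)c(O)c1)c1cc(OC)c(OC)c(OC)c1` gives 95 nM in a functional assay on HCT-116 cells (Homo sapiens) for inhibition, read by MTT assay, with a stated time of 48 h; on this read-out higher numbers stand for weaker inhibition and lower numbers for stronger inhibition. Compound 2 `C/C=C/C(=O)N(Cc1ccc(OC)c(C)c1)c1cc(OC)c(OC)c(OC)c1` gives 23500 nM in this assay. Compound 3 `COc1ccc(CN(C(=O)CCCCCl)c2cc(OC)c(OC)c(OC)c2)cc1O` gives 220 nM in this assay. Among these three numbers compound 3 stands second highest: its nearest neighbour is compound 1, separated by the step of a 2.3-fold higher number from compound 1 to compound 3 (0.36 log units; beyond the scatter), while compound 2 lies furthest away with a far higher number. Compound 4 `COc1ccc(CN(C(=O)CO)c2cc(OC)c(OC)c(OC)c2)cc1O` keeps the core of compound 3 but has hydroxy in place of 3-chloropropyl on a saturated chain carbon bound to a carbonyl carbon. Among the compounds with values here, only one measured step touches the group on the carbonyl carbon, the step of a 2.3-fold higher number from compound 1 to compound 3 (0.36 log units; beyond the scatter), and it was modest; but it exchanged one chain for another, whereas here a 3-chloropropyl leaves and a hydroxy enters, a change of a different kind that no measured pair covers. With so little to lean on, the direction is taken from the fact that every measured variation at this carbon moved the number in this assay away from compound 1. Compound 4 is expected to give a higher number, a step of a 9.1-fold higher number from compound 3 to compound 4 (0.96 log units; beyond the scatter) of uncertain size. Compound 4 is therefore estimated at 2000 nM, within a range from 300 nM to 12000 nM.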

Compound 4, half-maximal inhibitory concentration: 520 nM
Beside the measured number, compound 4's estimate is 3.8-fold (0.59 log units) above it, and the stated range covers the measured number.
By their numbers in this assay, from the lowest: compound 1; then compound 3; then compound 4; then compound 2.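

In this assay, putting a hydroxy in place of 3-chloropropyl on a saturated chain carbon bound to a carbonyl carbon gives a 2.4-fold higher number from compound 3 to compound 4 (0.37 log units; beyond the scatter) and counts as a modest change, even though 4 heavy atoms, one of them chlorine, leave and 1 oxygen enters with 1 hydrogen-bond donor and 1 hydrogen-bond acceptor. Set against the pent-1-en-1-yl group, hydroxymethyl on the carbonyl carbon gives a 5.5-fold higher number from compound 1 to compound 4 (0.74 log units; beyond the scatter) and this too is modest, so pent-1-en-1-yl, 4-chlorobutyl and hydroxymethyl all lie within modest steps of one another on the shared core. Nothing measured here explains why the number rises with this change.

Compound 3 and compound 4 differ in both chain length and end group, so the compounds shown do not separate the effect of losing the chlorine from that of shortening the chain, a question that a 4-hydroxybutyl group on the carbonyl carbon would address. On these data alone, how an aminomethyl group or a carboxylic acid at this place would compare also remains open.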